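Working notes on the hydroxyurea series

The compounds below may be only part of what the source reports. "The series", "measured", "known", "first", "only" and "open" are said of these compounds alone.

Measured so far in an assay (Cavia porcellus) for inhibition of Polyunsaturated fatty acid 5-lipoxygenase (Homo sapiens); on this read-out lower numbers stand for stronger inhibition and higher numbers for weaker inhibition:
compound 1, `NC(=O)N(O)CC1=Cc2cc(OCc3ccccc3)ccc2OC1`, gives 380 nM
compound 2, `C=CCNC(=O)N(O)CC1=Cc2cc(Oc3ccccc3)ccc2OC1`, gives 44 nM
compound 3, `CC1Oc2ccc(OCc3ccccc3)cc2C=C1CN(O)C(N)=O`, gives 260 nM

Compound 3 stands second highest of the three numbers. Among the measured compounds shown here, its nearest neighbour is compound 1, and the only single-change step in the set, a 1.5-fold lower number from compound 1 to compound 3 (0.16 log units; within the scatter), lies within the scatter, so these two cannot be told apart. Compound 2 stands furthest from compound 3, beyond the scatter, with the lower number.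

The next compound is compound 4, `CC1Oc2ccc(Oc3ccccc3)cc2C=C1CN(O)C(N)=O`. It differs from compound 3 by phenyl in place of benzyl on an oxygen on an aromatic ring. For the measured compounds named here, no measured pair isolates this change. Compound 1 carries benzyloxy and compound 2 carries phenoxy at the same oxygen, but compound 2 also bears an allyl on the urea nitrogen, so the difference between them mixes two changes: compound 1 gives 380 nM whereas compound 2 gives 44 nM. That comparison points toward a lower number for phenoxy without settling how much of it belongs to the oxygen change alone.

For compound 4 in this assay the expected step is therefore a 2.4-fold lower number from compound 3 to compound 4 (0.37 log units; beyond the scatter), toward the lower number. Compound 4 is estimated at 110 nM. For compound 4 the expected range runs from 35 nM to 330 nM.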

Compound 4, half-maximal inhibitory concentration: 87 nM
For compound 4 the middle estimate is 1.3-fold (0.10 log units) above the measured one, within the range that was stated.
By their numbers in this assay, from the lowest: compounds 2 and 4 (each within the scatter of the next); then compounds 3 and 1 (each within the scatter of the next).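

In this assay the benzyloxy to phenoxy change can now be read on its own, with the rest of the structure held fixed: a 3.0-fold lower number from compound 3 to compound 4 (0.48 log units; beyond the scatter) is a step beyond the scatter, for phenyl in place of benzyl on an oxygen on an aromatic ring. The earlier pair that pointed the same way, compound 1 and compound 2, mixed this change with an allyl on the urea nitrogen, whereas here the two groups differ by a single carbon, and the counts of hydrogen-bond donors and acceptors stay the same. The data at hand offer no measurement that would explain the step.

From the compounds shown here alone, compound 1 and compound 2 still mix two changes, so it stays open whether the step keeps its size without the methyl on the saturated ring carbon or with the allyl on the urea nitrogen, and what the allyl contributes on its own. Also open, going by these compounds, is how the number moves with other groups on this oxygen, such as a phenethyl chain, a pyridine ring or a plain methyl.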